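Extending the chain of compound 2

This account rests on a few compounds, and the source may have more. Where it says the series, first, only, none or still open, it means among the compounds named here.

Measured in a functional assay on EC9706 cells (Homo sapiens) for antiproliferative activity, read by MTT assay, with a stated time of 48 h; a higher number here means a weaker inhibitor, a lower number a stronger inhibitor:
- compound 1 `CCCCCCCCCn1cc(COC[C@@H]2OC[C@H](N)[C@@H]2O)nn1`: 20100 nM
- compound 2 `CCCCCCCCCn1cc(COC[C@@H]2OC[C@H](N)[C@H]2O)nn1`: > 128000 nM (a limit)

Compound 2 reads > 128000 nM, which is a limit of this assay and not a number.

Compound 3 `CCCCCCCCCCCCCCCCCCn1cc(COC[C@@H]2OC[C@H](N)[C@H]2O)nn1` keeps the configuration of compound 2 as drawn. The structural change is nonyl in place of hydrogen on a saturated chain carbon, nine bonds along the chain from an aromatic nitrogen.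

Going by the values given here, the only measured step, an at least 6.3-fold higher number from compound 1 to compound 2 (0.80 log units; beyond the scatter), is beyond the scatter, but it bears on this change only indirectly. It concerns (the fact that compounds 1 and 2 differ only in the configuration as drawn), and the chain stays the same in it. Among the compounds with values here, no measured step alters the chain, so the size of the change cannot be read from the data.

Compound 2 at > 128000 nM gives no number to start from, so a measurable result for compound 3 could only lie lower in this assay. Compound 3 may equally stay at the limit.

The expected change is an at least 2.1-fold lower number from compound 2 to compound 3 (0.32 log units; beyond the scatter), a rough estimate toward a stronger result. For compound 3 the estimated value is 60000 nM, with an expected range of 15000 nM to 128000 nM.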

Compound 3, half-maximal inhibitory concentration: 2290 nM
Estimate against measurement, compound 3: 26-fold (1.42 log units) above; measured number outside the range, below it.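

In this assay, going by these compounds alone, this is the first measured step that alters the chain, and it shows that the chain matters: placing nonyl on a saturated chain carbon, nine bonds along the chain from an aromatic nitrogen, gives an at least 55-fold lower number from compound 2 to compound 3 (1.74 log units; beyond the scatter). The earlier compounds shown here showed only that changing the configuration as drawn could move the result, while the chain stayed the same. Compound 2 gives > 128000 nM, which is a limit of this assay and not a number, so the step fixes a minimum size and the real difference could be larger, a caution that rests on one point: the limit of > 128000 nM in this assay, at which 1 of the 3 values shown sits.

Going by these compounds, compound 1 and compound 3 differ in two places, so their values cannot be compared directly, and the effect of the same longer chain on the configuration of compound 1 remains open. Also open, on these data alone, is how the result depends on the length and the end of the chain, for example with dodecyl or with a chain ending in an amine or a carboxylic acid.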